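Trimming the Side Chain of Compound 2

The compounds below may be only part of what the source reports. "The series", "measured", "known", "first", "only" and "open" are said of these compounds alone.

Of the compounds shown here, three have so far been tested in an ADME assay on MT2 cells (Homo sapiens) for cytotoxicity, read by MTT assay; a lower number here means that less compound is tolerated, a higher number that more compound is tolerated. Compound 1, `Clc1cccc(Cl)c1Cc1nnc(Nc2ccc(COCc3ccsc3)cc2)o1`, gives > 100000 nM, which is a limit of the assay rather than a number. Compound 2, `O=c1ncccn1SCCc1ccc(Nc2ncc(Cc3c(F)cccc3F)o2)cc1`, likewise gives > 100000 nM, again a limit. Among the measured compounds shown here, compound 3, `[O-][n+]1ccc(OCc2ccc(Nc3ncc(Cc4c(F)cccc4F)o3)cc2Cl)cc1`, is the only one with a measured number, 1700 nM. Compound 2 thus stands at the limit of > 100000 nM in this assay, at which 2 of the 3 values shown sit, and no number is known for it.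

Compound 4, `OCc1ccc(Nc2ncc(Cc3c(F)cccc3F)o2)cc1`, has not yet been measured in this assay. It differs from compound 2 in one place: one oxygen atom in place of a group of 9 heavy atoms (5 carbon, 2 nitrogen, 1 oxygen, 1 sulfur; one six-membered aromatic ring with 2 hetero atoms), on a saturated chain carbon bound to an aromatic carbon. Most of the side chain is removed, a hydroxy is left on the saturated chain carbon bound to an aromatic carbon, and the shared core is kept.

For the measured compounds named here, no step between measured compounds has been recorded, so nothing sets the size of this one directly. Compound 2 sits at the limit of > 100000 nM in this assay, at which 2 of the 3 values shown sit, and the change removes atoms rather than adding a ring or a charge. The expected step is therefore a number no higher from compound 2 to compound 4 (the limit leaves the size open), that is, none beyond the scatter. Compound 4 is estimated at 100000 nM, within 30000 nM to 300000 nM, and most likely it too will be reported only as a limit.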

Compound 4, half-maximal cytotoxic concentration: > 100000 nM
Compound 4 gave a limit, no number (the forecaster's own chance of this, stated with the estimate: 70%); the middle value sits exactly at the limit.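

Compound 2 and compound 4 both stand only as limits in this assay and not as numbers, so no step from one to the other can be read: the limit of > 100000 nM in this assay, at which 3 of the 4 values shown sit.

The compounds shown leave open how much of compound 2 or compound 4 is actually tolerated in this assay and whether replacing the side chain with a hydroxy changes that at all.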